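Pyrazoline amides bearing an indole: methoxy for methyl

The source may report more compounds than this note shows. Statements on the series, on what has been measured and on what is new or still open speak of the compounds shown alone.

Measured so far:
compound 1 `COc1ccc(C(=O)N2N=C(c3ccccc3)CC2c2cn(C)c3ccccc23)cn1`, 3980 nM
compound 2 `Cc1ccc(C(=O)N2N=C(c3ccccc3)CC2c2cn(C)c3ccccc23)cn1`, 2390 nM
compound 3 `COc1cccc(C2=NN(C(=O)c3ccc(C)nc3)C(c3cn(C)c4ccc(OC)cc34)C2)c1`, 34 nM

All three were run in a functional assay on HeLa cells (Homo sapiens) for inhibition, read by MTT assay, with a stated time of 48 h; a lower number here means a stronger inhibitor of growth, a higher number a weaker inhibitor of growth. Compound 2 and compound 1 share one scaffold and differ in a single place: methoxy in place of methyl on an aromatic carbon. The step of a 1.7-fold higher number from compound 2 to compound 1 (0.22 log units; within the scatter), so within this pair the exchange leaves the read-out essentially where it was.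

Compound 3 stands apart. In this assay compound 3 gives 34 nM, the lowest of the three numbers; its nearest neighbour is compound 2 and the gap to compound 1 is wider still, both gaps beyond the scatter. How the two cores of compound 2 and compound 3 differ is not broken down here.

Compound 4 `COc1cccc(C2=NN(C(=O)c3ccc(OC)nc3)C(c3cn(C)c4ccc(OC)cc34)C2)c1` is not yet measured. It carries the same change relative to compound 3 that compound 1 carries relative to compound 2: methoxy in place of methyl on an aromatic carbon. The two place descriptions agree word for word, so this is the same change on a different core.

Going by the values given here, the only measured instance of this change is the step from compound 2 to compound 1, which sat within the scatter. Among the compounds with values here, on that basis the expected step for compound 4 is a 1.5-fold higher number from compound 3 to compound 4 (0.17 log units; within the scatter), small and roughly neutral, because the one measured example, a 1.7-fold higher number from compound 2 to compound 1 (0.22 log units; within the scatter), moved little. The estimate for compound 4 in this assay is therefore 50 nM, with a likely range from 18 nM to 140 nM; one measured pair is a thin basis, so the range is kept wide.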

Compound 4, concentration for 50% growth inhibition: 340 nM
Beside the measured number, compound 4's estimate is 6.8-fold (0.83 log units) below it, and the stated range ends below it.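

In this assay, exchanging 6-methylpyridin-3-yl for 6-methoxypyridin-3-yl on the core of compound 3 gives a 10-fold higher number from compound 3 to compound 4 (1.00 log units; beyond the scatter), so methyl is the better of the two groups on this core. Set beside the earlier pair, the size of the step does not carry from one core to the other, and a near-neutral reading on the core of compound 2 is no safe guide to the core of compound 3: the same change on two cores in this assay, a 1.7-fold higher number (0.22 log units; within the scatter) from compound 2 to compound 1 and a 10-fold higher number (1.00 log units; beyond the scatter) from compound 3 to compound 4, 6.0-fold (0.78 log units) apart, beyond the scatter of two such steps

The comparison rests on a single pair per core, so it shows that the step depends on the core but not which feature of the core of compound 3 is responsible, nor why the step grows there.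

Still open, going by these compounds, is how other groups at this place on the core of compound 3 would read, for example an amine, a chlorine atom or a longer chain such as ethoxy. Also open, on these data alone, is whether the larger step belongs to the whole core of compound 3 or to only one part of what separates it from the core of compound 2, which would take pairs on intermediate cores to settle.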